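A few compounds are considered here, and "the series" means these few. Any claim that something is new, unique, unknown or untested is made for them only; others in the source may bear on it.

Compound 1 `Cc1ccc(/C=C/C(=O)Oc2ccc(/C=C3\CCCC(CN(C)C)C3=O)cc2)cc1` gives 1290 nM.
Compound 2 `COc1ccc(/C=C/C(=O)Oc2ccc(/C=C3\CCCC(CN(C)C)C3=O)cc2)cc1` gives 2410 nM.
Compound 3 `Cc1ccc(C(=O)Oc2ccc(/C=C3\CCCCC3=O)cc2)cc1` gives only > 50000 nM.

All three values come from a functional assay on P388 cells (Mus musculus); a higher number here means a weaker inhibitor, a lower number a stronger inhibitor. Compound 2 differs from compound 1 by methoxy in place of methyl on an aromatic carbon, a change that produced a 1.9-fold higher number from compound 1 to compound 2 (0.27 log units; within the scatter). Compound 4 `COc1ccc(C(=O)Oc2ccc(/C=C3\CCCCC3=O)cc2)cc1` is not yet measured in this assay; it stands to compound 3 in the same way, by methoxy in place of methyl on an aromatic carbon, and the place of the change is the same. The difference between the two cores is not broken down here. For compound 3 the assay reported only a limit, > 50000 nM, which is the limit of > 50000 nM in this assay, at which 1 of the 3 values shown sits. Because the same change gave a 1.9-fold higher number from compound 1 to compound 2 (0.27 log units; within the scatter), the expected step is a step that the limit leaves unreadable from compound 3 to compound 4. Compound 4 is therefore expected to give 80000 nM, most likely again only a limit, somewhere between 30000 nM and 300000 nM.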

Compound 4, half-maximal inhibitory concentration: > 50000 nM
Compound 4 was reported as a limit; the forecaster's own chance of this, stated with the estimate: 85%; the middle value does not contradict the limit.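

Compound 3 and compound 4 both reach only a limit in this assay, so no step between them can be read: the limit of > 50000 nM in this assay, at which 2 of the 4 values shown sit.

The compounds shown leave open whether methoxy in place of methyl changes anything on this core.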